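Substituent changes on the fused ring and maximal response

A few compounds are considered here, and "the series" means these few. Any claim that something is new, unique, unknown or untested is made for them only; others in the source may bear on it.

Measured compounds:
compound 1 `CC#C[C@@H](CC(=O)O)c1ccc(OC[C@H]2COc3ccccc3O2)cc1`, 70%
compound 2 `CC#C[C@@H](CC(=O)O)c1ccc(OC[C@H]2COc3ccc(Br)cc3O2)cc1`, 69%
compound 3 `CC#C[C@@H](CC(=O)O)c1ccc(OC[C@H]2COc3ccc(OC(C)C)cc3O2)cc1`, 90%

In a functional assay on HEK293 cells for agonist activity at Free fatty acid receptor 1 (Homo sapiens), read by fluorescence and calcium flux, with a stated time of 10 min (on this read-out lower numbers stand for smaller maximal responses and higher numbers for larger maximal responses), compound 3 gives the highest of the three numbers. The nearest is compound 1, with a number 20 percentage points higher from compound 1 to compound 3 (beyond the scatter), and the furthest is compound 2, with a number 21 percentage points higher from compound 2 to compound 3 (beyond the scatter); both steps are beyond the scatter and of modest size. The step of a number 1 percentage points lower from compound 1 to compound 2 (within the scatter) lies within the scatter, so a bromo and a hydrogen at that aromatic carbon give numbers that cannot be told apart.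

Compound 4 `CC#C[C@@H](CC(=O)O)c1ccc(OC[C@H]2COc3ccc(CO)cc3O2)cc1` differs from compound 3 in one place: hydroxymethyl in place of isopropoxy on an aromatic carbon. The two steps that bear on this position show that an isopropoxy there carries a modest gain relative to hydrogen or bromo. For the measured compounds named here, no measured compound carries a hydroxymethyl, so the direction is uncertain; the nearest guide is that a substituent other than isopropoxy has so far stood near compound 1 and compound 2. The expectation is therefore a modest drop, a number 12 percentage points lower from compound 3 to compound 4 (beyond the scatter), back toward those two. Compound 4 is estimated at 78%, with a range of 65% to 92%.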

Compound 4, largest response reached (Emax), in percent of the reference or control that the assay uses: 42%
For compound 4 the middle estimate is 36 percentage points above the measured one; measured number outside the range, below it.
By their numbers in this assay, from the lowest: compound 4; then compounds 2 and 1 (each within the scatter of the next); then compound 3.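

In this assay, this aromatic carbon can take the maximal response down as well as up: hydroxymethyl in place of hydrogen gives a number 28 percentage points lower from compound 1 to compound 4 (beyond the scatter), and hydroxymethyl in place of bromo gives a number 27 percentage points lower from compound 2 to compound 4 (beyond the scatter). The position is therefore not one where only isopropoxy makes a difference, since hydrogen and bromo, which could not be told apart, both stand clear of hydroxymethyl. Against isopropoxy the same change gives a number 48 percentage points lower from compound 3 to compound 4 (beyond the scatter), so the substituents at this carbon spread the response in both directions from hydrogen.

On these data alone, it remains open whether the drop follows the hydroxyl of hydroxymethyl or the shorter group, a question that a methoxymethyl, an aminomethyl or a longer alkoxy chain such as butoxy at this carbon would address. No evidence on the cause of the drop is at hand.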